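The source may report more compounds than this note shows. Statements on the series, on what has been measured and on what is new or still open speak of the compounds shown alone.

Compound 1 `Cc1nn(C)c(Oc2cccc(F)c2)c1/C=N\CCCCCOc1cc2oc(=O)cc(C)c2cc1Cl` gives 9870 nM in a functional assay on U-87MG ATCC cells for antiproliferative activity against U-87 MG (Homo sapiens), read by MTT assay, with a stated time of 72 h; on this read-out higher numbers stand for weaker inhibition and lower numbers for stronger inhibition.
Compound 2 `Cc1nn(C)c(Oc2ccc(Cl)cc2)c1/C=N\CCCCCOc1cc2oc(=O)cc(C)c2cc1Cl` gives 18700 nM in this assay.
Compound 3 `Cc1nn(C)c(Oc2ccc(F)c(F)c2)c1/C=N\CCCCCCOc1cc2oc(=O)cc(C)c2cc1Cl` gives > 25000 nM in this assay; this is a limit of the assay, not a number.

The three compounds share one core and differ in the aryl group on the oxygen on the aromatic ring and in the length of the chain linking to the coumarin-bearing part. Within the data shown here, the only measured step between neighbours that differ in one place is a 1.9-fold higher number from compound 1 to compound 2 (0.28 log units; within the scatter), which lies within the scatter. Compound 3 stands apart: for it only a limit is known, (the limit of > 25000 nM in this assay, at which 1 of the 3 values shown sits), so nothing can be said about its order relative to compound 1 or compound 2.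

Compound 4 `Cc1ccc(Oc2c(/C=N\CCCCCCOc3cc4oc(=O)cc(C)c4cc3Cl)c(C)nn2C)cc1` is compound 3 with 4-methylphenyl in place of 3,4-difluorophenyl on an oxygen on an aromatic ring. Among the measured compounds shown here, the one measured step that bears on this, the exchange of one aryl group for another in a 1.9-fold higher number from compound 1 to compound 2 (0.28 log units; within the scatter), was within the scatter, so no step beyond the scatter is expected in this assay from an aryl exchange alone. Because compound 3 sits at the limit (the limit of > 25000 nM in this assay, at which 1 of the 3 values shown sits), the starting point itself is uncertain. Compound 4 is therefore expected to give about 22000 nM, within 8000 nM to 60000 nM, which means an expected step of an at least 1.1-fold lower number from compound 3 to compound 4 (0.05 log units; that floor lies within the scatter).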

Compound 4, half-maximal inhibitory concentration: 23600 nM
For compound 4 the middle estimate is 1.1-fold (0.03 log units) below the measured one; low and high end bracket the measured number.
By their numbers in this assay, from the lowest: compounds 1, 2 and 4 (each within the scatter of the next, the first and the last beyond it). At a limit, above all of these: compound 3.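

Exchanging 3,4-difluorophenyl for 4-methylphenyl on an oxygen on an aromatic ring gives an at least 1.0-fold lower number from compound 3 to compound 4 (0.02 log units; that floor lies within the scatter) in this assay. For compound 3 the reading of > 25000 nM is a limit of the assay, not a number. Compound 4 is the first compound on the chain of compound 3 to give a number rather than a limit, which shows that the aryl group at this position can be changed on this chain and still yield a measured value, but the real size of the step remains unknown, as its only floor lies within the scatter and its starting point is a limit: the limit of > 25000 nM in this assay, at which 1 of the 4 values shown sits.

The compounds shown leave open whether a phenyl ring carrying an amine or a carboxylic acid at this oxygen, in place of the methyl or the halogens, would shift the number in this assay beyond the scatter. Also open, going by these compounds, is what the length of the chain does by itself when the aryl group is held fixed, and whether a longer chain would follow the same course.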